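Adding a Second Chloro Group to a Shared Core

This account rests on a few compounds, and the source may have more. Where it says the series, first, only, none or still open, it means among the compounds named here.

Compound 1 `ClCc1cccc(Cn2cnc3ncnc(Cl)c32)c1`: 6760 nM
Compound 2 `ClCc1cccc(Cn2cnc3c(Cl)ncnc32)c1`: 8120 nM
Compound 3 `ClCc1cccc(Cn2cnc3c(Cl)nc(Cl)nc32)c1`: 7240 nM

All three were tested in a functional assay on MDA-MB-231 cells (Homo sapiens) for cytotoxicity, read by sulforhodamine B assay, with a stated time of 48 h; on this read-out higher numbers stand for lower toxicity in this test and lower numbers for higher toxicity in this test. The three numbers lie close together, and every pair is within the usual scatter, so none of them can be told apart by this test. Compound 1 and compound 2 share the same atoms joined differently; the difference between the two cores is not broken down here. Compound 3 carries, relative to compound 2, (chloro in place of hydrogen on an aromatic carbon), and this gave a 1.1-fold lower number from compound 2 to compound 3 (0.05 log units; within the scatter).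

Compound 4 `ClCc1cccc(Cn2cnc3nc(Cl)nc(Cl)c32)c1` has not yet been measured. Among the measured compounds shown here, it differs from compound 1 by chloro in place of hydrogen on an aromatic carbon, the same change, at the same kind of place, as the one from compound 2 to compound 3. Because that earlier step was a 1.1-fold lower number from compound 2 to compound 3 (0.05 log units; within the scatter), a similarly small movement is expected here, namely a 1.1-fold lower number from compound 1 to compound 4 (0.04 log units; within the scatter). In this assay compound 4 is therefore estimated to give 6200 nM, with a likely range from 3100 nM to 12400 nM.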

Compound 4, concentration lethal to 50% of the cells: 4160 nM
Compound 4: the middle estimate sits 1.5-fold (0.17 log units) above what was measured; low and high end bracket the measured number.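

In this assay, placing the chloro group on the carbon between two ring nitrogen atoms in the core of compound 1 gave a 1.6-fold lower number from compound 1 to compound 4 (0.21 log units; within the scatter), a step too small to count as a real change. Set beside the earlier step on the other core, the same change shows no measurable difference between the two cores: the same change on two cores in this assay, a 1.1-fold lower number (0.05 log units; within the scatter) from compound 2 to compound 3 and a 1.6-fold lower number (0.21 log units; within the scatter) from compound 1 to compound 4, 1.4-fold (0.16 log units) apart, within the scatter of two such steps. This shows that, for these two cores, the change carried over with no difference this test can detect, but it does not show that the chloro group alters toxicity at all, nor that the two cores would stay alike under a change with a larger effect.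

As far as these compounds go, only hydrogen and chloro appear at this ring position, so it remains open whether an amine or a longer chain there would move the number beyond the scatter. All four compounds also share the chloromethyl group, which leaves open what a plain methyl or a hydroxymethyl group in its place would do.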